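The source may report more compounds than this note shows. Statements on the series, on what has been measured and on what is new or still open speak of the compounds shown alone.

Compound 3 `CC(C)(C)c1ccc(NC(=O)c2ccc(-c3ncccc3C(=O)O)cc2)cc1` carries a carboxy group on the core shared with compound 1 `CCCOc1cccnc1-c1ccc(C(=O)Nc2ccc(C(C)(C)C)cc2)cc1` and compound 2 `CCS(=O)(=O)Nc1cccnc1-c1ccc(C(=O)Nc2ccc(C(C)(C)C)cc2)cc1`. In a functional assay for antagonist activity at transient receptor potential cation channel subfamily V member 1 (Homo sapiens), read by FLIPR (a higher number here means a weaker inhibitor, a lower number a stronger inhibitor), compound 3 gives only > 4000 nM, a limit of the assay and not a number. Compound 1 gives 62 nM and compound 2 gives 49 nM; the steps of an at least 64-fold higher number from compound 1 to compound 3 (1.80 log units; beyond the scatter) and an at least 81-fold higher number from compound 2 to compound 3 (1.91 log units; beyond the scatter) are large losses, whereas a 1.3-fold lower number from compound 1 to compound 2 (0.10 log units; within the scatter) stays within the scatter. Compound 4 `CN(C)Cc1cccnc1-c1ccc(C(=O)Nc2ccc(C(C)(C)C)cc2)cc1` differs from compound 3 by (dimethylamino)methyl in place of carboxy on an aromatic carbon. Going by the values given here, no measured step covers this pair; the substituents of compounds 1 and 2 sit in one range, the carboxy at the limit (the limit of > 4000 nM in this assay, at which 1 of the 3 values shown sits). For compound 4 a recovery toward that range is expected, an at least 10-fold lower number from compound 3 to compound 4 (1.00 log units; beyond the scatter), with wide uncertainty. Compound 4 is estimated at 400 nM, between 60 nM and 3000 nM.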

Compound 4, half-maximal inhibitory concentration in the transient receptor potential cation channel subfamily V member 1 assay: 746 nM
The estimate for compound 4 lay 1.9-fold (0.27 log units) below the measured number; the measured number falls inside the stated range.
By their numbers in the transient receptor potential cation channel subfamily V member 1 assay, from the lowest: compounds 2 and 1 (each within the scatter of the next); then compound 4. At a limit, above all of these: compound 3.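

In the transient receptor potential cation channel subfamily V member 1 assay, (dimethylamino)methyl on this aromatic carbon gives a measurable number where carboxy does not, an at least 5.3-fold lower number from compound 3 to compound 4 (0.72 log units; beyond the scatter), a step that is only a bound since compound 3 sits at a limit of the assay. The recovery is partial in the transient receptor potential cation channel subfamily V member 1 assay: a 15-fold higher number from compound 2 to compound 4 (1.18 log units; beyond the scatter) and a 12-fold higher number from compound 1 to compound 4 (1.08 log units; beyond the scatter). In a physicochemical assay for solubility, at pH 7.4 (on this read-out lower numbers stand for lower solubility and higher numbers for higher solubility), compound 3 gives 104 ug/mL and compound 4 gives 50 ug/mL. This change also gives up solubility in the physicochemical assay: the measured solubility of compound 3, 104 ug/mL, and of compound 4, 50 ug/mL, a 2.1-fold lower number (0.32 log units; beyond the scatter)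

The compounds shown leave open whether a primary amine, or a longer chain ending in dimethylamino, at this position would return to the range of compound 1 and compound 2.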